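The source may report more compounds than this note shows. Statements on the series, on what has been measured and on what is new or still open speak of the compounds shown alone.

Compound 1, whose structure is `CCCSc1nc(Cl)c2c(n1)N(Cc1ccccc1)C(C(=O)NCCNC(=O)OC(C)(C)C)N2`, gives 29700 nM in a functional assay on PC-3 cells (Homo sapiens) for antiproliferative activity, read by MTT assay, with a stated time of 72 h; a lower number here means a stronger inhibitor, a higher number a weaker inhibitor. That is the highest of the two numbers shown: compound 3, `CCCSc1nc(Cl)c2c(n1)N(Cc1ccco1)C(C(=O)N1CCN(C)CC1)N2`, gives 11400 nM in this assay, a lower number that lies beyond the scatter. Compound 2, `CCCSc1nc(Cl)c2c(n1)N(CCNC(=O)OC(C)(C)C)C(C(=O)N1CCN(C)CC1)N2`, reaches only the limit of this assay, > 64000 nM, and no number is known for it.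

Within the data shown here, the single step between measured compounds that differ in one place runs from compound 2 to compound 3, where an at least 5.6-fold lower number from compound 2 to compound 3 (0.74 log units; beyond the scatter); it touches the substituent on the ring nitrogen, not the amide side chain, and rests on (the limit of > 64000 nM in this assay, at which 1 of the 3 values shown sits).

Compound 4, `CCCSc1nc(Cl)c2c(n1)N(Cc1ccccc1)C(C(=O)NCCCc1ccccc1)N2`, is not yet measured. It differs from compound 1 by benzyl in place of (tert-butoxycarbonyl)amino on a saturated chain carbon, two bonds along the chain from an amide-type nitrogen. Among the measured compounds shown here, the one measured step, from compound 2 to compound 3, exchanged a carbamate-bearing chain for an aromatic ring and gave a lower number, though at a different place, so only a loose guide exists for this new change. Compound 4 is therefore expected to give a somewhat lower number than compound 1, as a 2.0-fold lower number from compound 1 to compound 4 (0.30 log units; within the scatter). The estimate for compound 4 in this assay is 15000 nM, within a range from 5000 nM to 45000 nM.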

Compound 4, half-maximal inhibitory concentration: 12700 nM
Beside the measured number, compound 4's estimate is 1.2-fold (0.07 log units) above it, within the range that was stated.
By their numbers in this assay, from the lowest: compounds 3 and 4 (each within the scatter of the next); then compound 1. At a limit, above all of these: compound 2.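

In this assay the amide side chain now has a measured step of its own, since the earlier step touched only the substituent on the ring nitrogen: a 2.3-fold lower number from compound 1 to compound 4 (0.37 log units; beyond the scatter). The exchange removes (tert-butoxycarbonyl)amino, with its hydrogen-bond donor and acceptors, and places benzyl, which has neither, on a saturated chain carbon, two bonds along the chain from an amide-type nitrogen, so in this pair the carbamate is not needed for the activity seen, and an aromatic ring at this place is tolerated. Nothing shown here accounts for the modest difference between the two compounds.

As far as these compounds go, it remains open whether the lower number comes from gaining the phenyl ring or from losing the carbamate, a question that a free primary amine, a carboxylic acid or a cyclohexyl group at the same place would help to settle. Also open, from the compounds shown here alone, is how far the chain length matters, as a shorter or longer chain carrying the same phenyl ring would show, and whether the step holds when the benzyl group on the ring nitrogen is replaced by another group.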